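The compounds below may be only part of what the source reports. "The series", "measured", "known", "first", "only" and "open" are said of these compounds alone.

Working notes on the series. All four compounds share one core: compound 1 `C=C(Br)C(=O)Nc1ccc(/C=C2\SC(=O)N(Cc3ccc(C)cc3)C2=O)cc1`, compound 2 `C=C(Br)C(=O)Nc1ccc(/C=C2\SC(=O)N(Cc3ccc(Cl)cc3)C2=O)cc1` and compound 3 `Nc1ccc(/C=C2\SC(=O)N(Cc3ccc(Cl)cc3)C2=O)cc1` have been measured, compound 4 `Cc1ccc(CN2C(=O)S/C(=C\c3ccc(N)cc3)C2=O)cc1` has not. In a functional assay on FM3A cells (Mus musculus) for cytotoxicity, read by cell counting, with a stated time of 2 days (a higher number here means a weaker inhibitor, a lower number a stronger inhibitor), compound 1 gives 6100 nM. In this assay compound 2 gives 5100 nM. In this assay compound 3 gives 60000 nM, the highest number of the three measured compounds, with its steps to both others beyond the scatter.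

Two structural changes are covered by the measured pairs. The first, (methyl in place of chloro on an aromatic carbon), produces a 1.2-fold higher number from compound 2 to compound 1 (0.08 log units; within the scatter). The second, (hydrogen in place of (1-bromoethenyl)carbonyl on a nitrogen on an aromatic ring), produces a 12-fold higher number from compound 2 to compound 3 (1.07 log units; beyond the scatter); this is also how the core of compound 3 differs from the core of compound 2.

Compound 4 differs from compound 3 by methyl in place of chloro on an aromatic carbon. This is the same change, at the same place, as the one between compound 2 and compound 1, and it occurs twice in all among these compounds. Going by the values given here, the single measured instance of it, a 1.2-fold higher number from compound 2 to compound 1 (0.08 log units; within the scatter), lies within the scatter. A step of similar size is therefore expected in this assay, namely a 1.2-fold higher number from compound 3 to compound 4 (0.07 log units; within the scatter). The expectation rests on one pair only and is correspondingly weak. Compound 4 is estimated to give 70000 nM in this assay, with a range expected from 35000 nM to 140000 nM.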

Compound 4, half-maximal inhibitory concentration: > 250000 nM
Compound 4 gave a limit, no number; the forecaster's own chance of this, stated with the estimate: 15%; middle value at least 3.5-fold (0.55 log units) away from the limit.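

In this assay, methyl in place of chloro gives an at least 4.1-fold higher number from compound 3 to compound 4 (0.61 log units; beyond the scatter), so this change does not carry over unchanged from the core of compound 2 to the core of compound 3: the same change on two cores in this assay, a 1.2-fold higher number (0.08 log units; within the scatter) from compound 2 to compound 1 and an at least 4.1-fold higher number (0.61 log units; beyond the scatter) from compound 3 to compound 4, at least 3.4-fold (0.54 log units) apart, beyond the scatter of two such steps Hydrogen in place of (1-bromoethenyl)carbonyl on the nitrogen gives an at least 40-fold higher number from compound 1 to compound 4 (1.61 log units; beyond the scatter), so this change, too, differs with the core that carries it: the same change on two cores in this assay, a 12-fold higher number (1.07 log units; beyond the scatter) from compound 2 to compound 3 and an at least 40-fold higher number (1.61 log units; beyond the scatter) from compound 1 to compound 4, at least 3.4-fold (0.54 log units) apart, beyond the scatter of two such steps Compound 4 gave a limit and not a number, so both gaps are known only as lower bounds, and two pairs on two cores show that the steps differ, but not why they differ or whether the difference extends to other cores: the limit of > 250000 nM in this assay, at which 1 of the 4 values shown sits.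

The compounds shown leave open how a fluoro or a methoxy group in place of chloro on that aromatic carbon would behave on either core. They also leave open whether an acetyl group in place of (1-bromoethenyl)carbonyl on the nitrogen would give values nearer those of compound 1 and compound 2 or nearer that of compound 3.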